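Swapping a Nitro for a tert-Butyl on a Benzyl Thioether

The compounds below may be only part of what the source reports. "The series", "measured", "known", "first", "only" and "open" are said of these compounds alone.

Measured compounds:
compound 1, `C#CCSc1nc2cc(Cl)c(Cl)cc2n1C1O[C@H](CO)[C@@H](O)[C@H]1O`: 60000 nM
compound 2, `O=[N+]([O-])c1ccc(CSc2nc3cc(Cl)c(Cl)cc3n2C2O[C@H](CO)[C@@H](O)[C@H]2O)cc1`: 30000 nM

For the measured compounds named here, in a functional assay on KB cells (Homo sapiens) for inhibition (on this read-out higher numbers stand for weaker inhibition and lower numbers for stronger inhibition), compound 2 holds the lowest of the two numbers, though the only measured step, a 2.0-fold lower number from compound 1 to compound 2 (0.30 log units; within the scatter), stays within the scatter. Compound 3, `CC(C)(C)c1ccc(CSc2nc3cc(Cl)c(Cl)cc3n2C2O[C@H](CO)[C@@H](O)[C@H]2O)cc1`, differs from compound 2 by tert-butyl in place of nitro on an aromatic carbon. Going by the values given here, no measured step covers a change of this kind, and the one step available gives no movement beyond the scatter. Compound 3 is therefore expected to show no change at the digits printed from compound 2 to compound 3 (within the scatter). Compound 3 is estimated at 30000 nM, with a range from 10000 nM to 90000 nM.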

Compound 3, half-maximal inhibitory concentration: 50000 nM
For compound 3 the middle estimate is 1.7-fold (0.22 log units) below the measured one; low and high end bracket the measured number.
By their numbers in this assay, from the lowest: compounds 2, 3 and 1 (each within the scatter of the next).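

In this assay the swap gives a 1.7-fold higher number from compound 2 to compound 3 (0.22 log units; within the scatter) and so separates neither group on this aromatic carbon, although nitro brings hydrogen-bond acceptors and tert-butyl none. The second aryl group on the sulfur-bound chain carbon behaves likewise, with a 1.2-fold lower number from compound 1 to compound 3 (0.08 log units; within the scatter) and no difference from ethynyl that can be read. Nothing available gives a reason for this flat result. Still open, going by these compounds, is whether an amine or a carboxylic acid on that aromatic carbon would move the number beyond the scatter.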